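From 4-hydroxyphenyl to 2,4-dichlorophenyl on a shared core

The source may report more compounds than this note shows. Statements on the series, on what has been measured and on what is new or still open speak of the compounds shown alone.

- compound 1 `O=c1oc2ccccc2c2nc3c(ccc4cc[nH]c43)c(-c3cccnc3Cl)c12` gives 70700 nM
- compound 2 `O=c1oc2ccccc2c2nc3c(ccc4cc[nH]c43)c(-c3cccc(Br)c3)c12` gives 70700 nM
- compound 3 `O=c1oc2ccccc2c2nc3c(ccc4cc[nH]c43)c(-c3ccc(O)cc3)c12` gives 70700 nM

These three numbers come from a functional assay on B16-F10 cells (Mus musculus) for cytotoxicity (a higher number here means a weaker inhibitor, a lower number a stronger inhibitor), and they are identical, so compound 3 stands level with compound 1 and compound 2. Compound 4 `O=c1oc2ccccc2c2nc3c(ccc4cc[nH]c43)c(-c3ccc(Cl)cc3Cl)c12` keeps the shared core and puts 2,4-dichlorophenyl in place of 4-hydroxyphenyl on an aromatic carbon.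

Three measured swaps of the ring at this same place bear on the question. They are no change at the digits printed from compound 1 to compound 2 (within the scatter) and no change at the digits printed from compound 1 to compound 3 (within the scatter) and no change at the digits printed from compound 2 to compound 3 (within the scatter) in turn. None of them moved the number, whether the ring carried chlorine, bromine or a hydroxyl group. Within the data shown here, no measured compound has two chlorines on this ring, so the new group is untested and the range must stay wide. The expected result is therefore no step beyond the scatter, with any surprise more likely toward a stronger value. The estimated change is a 1.1-fold lower number from compound 3 to compound 4 (0.06 log units; within the scatter) in this case. For compound 4 the expected value is 62000 nM with an estimated range from 25000 nM to 90000 nM as its span.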

Compound 4, half-maximal inhibitory concentration: 70700 nM
Beside the measured number, compound 4's estimate is 1.1-fold (0.06 log units) below it; measured number inside the range.
By their numbers in this assay, from the lowest: compounds 1, 2, 3 and 4 (each within the scatter of the next).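

In this assay, putting 2,4-dichlorophenyl on this carbon gives no change at the digits printed from compound 3 to compound 4 (within the scatter), no change at the digits printed from compound 2 to compound 4 (within the scatter) and no change at the digits printed from compound 1 to compound 4 (within the scatter). The earlier rings each carried a single chlorine, bromine or hydroxyl group, so this result extends the flat picture to a ring with two chlorines. Nothing available explains why these four compounds read alike.

Going by these compounds, it remains open whether a different kind of group on this carbon, such as an amine, a carboxylic acid or a longer chain in place of the aromatic ring, would separate itself from these four compounds. On these data alone, it is also open whether these same ring swaps would still read alike on a core altered elsewhere.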